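This account rests on a few compounds, and the source may have more. Where it says the series, first, only, none or still open, it means among the compounds named here.

Of the compounds shown here, two share one fused core and have been measured in an assay on isolated protein for inhibition of protein kinase C zeta type (Homo sapiens), read by mobility shift assay, tested at 30 uM; on this read-out lower numbers stand for less inhibition and higher numbers for more inhibition at the one concentration tested (going by the name of the read-out). Compound 1, with the structure `Cc1cc2[nH]nc(N)c2c(=O)[nH]1`, carries a methyl group on that core and gives 10% in this assay. Compound 2, with the structure `COc1cccc(-c2cc3[nH]nc(N)c3c(=O)[nH]2)c1`, carries a methoxyphenyl group at the corresponding position instead and gives -1% in this assay. Of the two numbers, compound 1 stands highest, and the value of compound 2 lies below it by more than the usual scatter of repeated measurements, so the two readings are distinguishable, though both sit at the low end of the inhibition scale.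

Compound 3, with the structure `Nc1n[nH]c2cc(-c3cccs3)[nH]c(=O)c12`, has not yet been measured in this assay. It differs from compound 1 in one place: thiophen-2-yl in place of methyl on an aromatic carbon. Going by the values given here, no measured step exists for this exact exchange, so the expectation rests on the values of compound 1 and compound 2 alone. Since compound 2 gives -1% with a larger aromatic ring in place of methyl, compound 3 is expected to give a somewhat lower number than compound 1, a step of a number 7 percentage points lower from compound 1 to compound 3 (within the scatter) in this assay, with 3% estimated, in a range from -8% to 15%.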

Compound 3, a percentage reported as inhibition, at one concentration (the size of the read-out at that concentration, not a potency): -27%
For compound 3 the middle estimate is 30 percentage points above the measured one; measured number below the stated range.
By their numbers in this assay, from the lowest: compound 3; then compound 2; then compound 1.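

In this assay, going by these compounds alone, putting thiophen-2-yl in place of methyl on an aromatic carbon next to the ring nitrogen gives a number 37 percentage points lower from compound 1 to compound 3 (beyond the scatter), the first step at this position that traces a single exchange, and it shows that the reading here depends strongly on the group attached. The earlier pair could suggest that any aromatic ring at this position would give a reading near zero, but the two aromatic groups give different numbers: compound 2, with methoxyphenyl, gives -1%, while compound 3, with thiophen-2-yl, gives -27%, and both are readings at a single concentration, not potencies. Nothing measured here explains why the thiophen-2-yl exchange has this effect.

The compounds shown leave open how a small non-aromatic group at this position, such as an ethyl group, an amine or a carboxylic acid, would read compared with methyl. They also leave open whether any group here can lift inhibition clearly past the modest level of compound 1, which gives 10% in this same test, or whether the negative reading of compound 3 holds up on repetition.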